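The source may hold more compounds than are shown below. What is called first, only, known or untested is meant among the compounds shown, and "the series" means these compounds.

Measured compounds:
compound 1, `CC(=O)c1cc(CC2CO2)c(OCCCCC#N)cc1O`, giving 62% in an assay on isolated protein for inhibition of leukotriene B4 receptor 1 (Homo sapiens), tested at 10 uM; on this read-out lower numbers stand for less inhibition and higher numbers for more inhibition at the one concentration tested (going by the name of the read-out);
compound 2, `C=CCc1cc(C(C)=O)c(O)cc1OCC#N`, giving 20% in this assay;
compound 3, `CCc1cc(C(C)=O)c(O)cc1OCCCCCC(C)(C)C#N`, giving 85% in this assay.

Compound 2 stands lowest of the three numbers. Its nearest neighbour is compound 1, whose number is higher by a margin beyond the scatter, and compound 3 lies further still above it, also beyond the scatter. Compound 4, `C=CCc1cc(C(C)=O)c(O)cc1OCCCCC`, has not been measured. It differs from compound 2 in one place: butyl in place of cyano on a saturated chain carbon bound to an oxygen on an aromatic ring. Cut one bond further out, the same change reads cyanomethyl to pentyl, or cyanomethoxy to pentyloxy.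

Among the measured compounds shown here, no step between measured compounds is available to anchor this change directly, and no pattern beyond the three compounds is claimed. Because compound 1 gives 62% and compound 3 gives 85%, both well above compound 2, an upward step is expected in this assay, of a size beyond the scatter but uncertain. The estimated step of a number 30 percentage points higher from compound 2 to compound 4 (beyond the scatter) carries that expectation. Compound 4 is therefore expected to give 50%, within a range from 25% to 75%.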

Compound 4, a percentage reported as inhibition, at one concentration (the size of the read-out at that concentration, not a potency): 60%
The estimate for compound 4 lay 10 percentage points below the measured number, and the stated range covers the measured number.
By their numbers in this assay, from the lowest: compound 2; then compounds 4 and 1 (each within the scatter of the next); then compound 3.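

In this assay, among the compounds shown here, butyl in place of cyano on a saturated chain carbon bound to an oxygen on an aromatic ring gives a number 40 percentage points higher from compound 2 to compound 4 (beyond the scatter), so this position responds strongly to the change, and this is the only comparison here between compounds that differ in one place. The change removes the triple bond and the hydrogen-bond acceptor of the cyano group while also bringing in a larger group of carbon atoms, and this single step cannot tell these differences apart. Nothing available explains why the number rises.

As far as these compounds go, it remains open whether the step follows from losing the cyano group or from gaining the butyl group. From the compounds shown here alone, how a carboxylic acid, an amine or a longer chain at this place would read in this assay also remains open.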